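A few compounds are considered here, and "the series" means these few. Any claim that something is new, unique, unknown or untested is made for them only; others in the source may bear on it.

Measured in a functional assay on OVCAR-3 cells (Homo sapiens) for antiproliferative activity; a lower number here means a stronger inhibitor of growth, a higher number a weaker inhibitor of growth:
- Compound 1 `Cc1ccc2c(O)cc(-c3cccc(Cl)c3)nc2n1`: < 10 nM (a limit)
- Compound 2 `Cc1ccnc2nc(-c3ccc4ccccc4c3)cc(O)c12`: 1290 nM

Among the measured compounds shown here, compound 2, at 1290 nM, holds the only exact number so far. Compound 3 `Cc1cc(C)c2c(O)cc(-c3ccc4ccccc4c3)nc2n1` differs from it by methyl in place of hydrogen on an aromatic carbon, next to the ring nitrogen (methyl in place of hydrogen on an aromatic carbon). For the measured compounds named here, no measured step shows what this change does. Compound 1, which differs elsewhere too, has a methyl group in that place and reads < 10 nM, a limit of the assay. A modest step toward stronger growth inhibition in this assay is therefore expected, possibly none beyond the scatter. For compound 3 the estimated value is 700 nM, with an expected range of 150 nM to 3000 nM.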

Compound 3, concentration for 50% growth inhibition: 20000 nM
Compound 3: middle estimate off by 29-fold (1.46 log units), on the low side; the measured number lies above the stated range.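

In this assay, among the compounds shown here, methyl in place of hydrogen on an aromatic carbon, next to the ring nitrogen, gives a 16-fold higher number from compound 2 to compound 3 (1.19 log units; beyond the scatter), the first measured step at this position, and it shows that the position is sensitive to this change in this pair. A methyl group in that place therefore cannot by itself be read as a sign of strong growth inhibition. Compound 1 differs elsewhere too, and its reading is only a limit: the limit of < 10 nM in this assay, at which 1 of the 3 values shown sits.

Going by these compounds, whether an ethyl group, a methoxy group or an amine at this position would read differently remains open. So does whether removing this methyl group from compound 1 would produce a step of similar size.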